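Swapping a phenoxy for a lactam on a fused core

The source may hold more compounds than are shown below. What is called first, only, known or untested is meant among the compounds shown, and "the series" means these compounds.

Of the compounds shown here, three have been measured in a physicochemical assay for lipophilicity, using the shake flask method, in phosphate buffer, measured as octanol-water partition, with a stated time of 30 min, at pH 7.4; a lower number here means a more polar compound, a higher number a more lipophilic compound. Compound 1 `Cc1nccn1-c1cnc(NCc2c(F)ccc3c2CCO3)c2cn[nH]c(=O)c12` gives 2.1. Compound 3 `Cc1nc(CN(C)C)ccc1-c1cnc(NCc2c(F)ccc3c2CCO3)c2cn[nH]c(=O)c12` shares the core of compound 1; in this assay compound 3 gives 2, and the change from compound 1 to compound 3 is a number 0.10 log units lower from compound 1 to compound 3 (within the scatter). Compound 2 `Fc1ccc2c(c1CNc1ncc(Oc3ccccc3)c3nncn13)CCO2` has a different core and gives 3.5; this is the highest of the three numbers, lying beyond the scatter above compound 1 and compound 3.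

Compound 4 `C[C@@H]1CC(=O)N(c2cnc(NCc3c(F)ccc4c3CCO4)n3cnnc23)C1` is not yet measured. It keeps the core of compound 2 and differs from it in one place: 4-methyl-2-oxopyrrolidin-1-yl in place of phenoxy on an aromatic carbon. A six-membered aromatic ring of carbon only leaves and a five-membered non-aromatic ring with one nitrogen and a carbonyl enters, with the count of hydrogen-bond acceptors unchanged.

Within the data shown here, none of the measured steps covers this change. Among the measured compounds shown here, the only measured step, from compound 1 to compound 3, concerns a different core and different groups and so offers no direct guide. The step from compound 2 to compound 4 is therefore estimated from the structural change alone, and it is expected to be a number 1.70 log units lower from compound 2 to compound 4 (beyond the scatter), a drop well beyond the scatter. Compound 4 is expected to give about 1.8, in a range from 1.2 to 2.4.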

Compound 4, distribution coefficient: 1.8
For compound 4 middle estimate and measured number coincide at the digits printed; the range from low to high includes it.
By their numbers in this assay, from the lowest: compounds 4, 3 and 1 (each within the scatter of the next); then compound 2.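

Placing 4-methyl-2-oxopyrrolidin-1-yl in place of phenoxy, on the aromatic carbon para to a large group, gives in this assay a number 1.70 log units lower from compound 2 to compound 4 (beyond the scatter). This is the first step among these compounds to lie beyond the scatter, as the only earlier step, on the core of compound 1, stayed within it, and it shows that this position on the core of compound 2 can respond strongly to a change of group, even though the groups that leave and enter have the same count of heavy atoms and of hydrogen-bond acceptors and neither carries a net charge. What does differ in the counted features is the six-membered aromatic ring of carbon only against a five-membered non-aromatic ring with a carbonyl, a methyl and a defined stereocentre, and nothing measured here explains why the number moves so far.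

Which of these features accounts for the step remains open, and a plain pyrrolidin-1-yl group or a cyclohexyloxy group at this place would help to separate them. Also open, going by these compounds, is whether the opposite stereoisomer of the methyl group, or an unsubstituted 2-oxopyrrolidin-1-yl group, would give a similar number.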